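The source may report more compounds than this note shows. Statements on the series, on what has been measured and on what is new or still open speak of the compounds shown alone.

Measured so far:
Compound 1, `Cc1ccc(NS(=O)(=O)c2cccc(C(F)(F)F)c2)cc1O`: 7100 nM
Compound 2, `COc1cc(C)c(S(=O)(=O)Nc2cccc(O)c2)cc1C`: 6900 nM

Both values come from an assay on HEK293 cells for inhibition of 17-beta-hydroxysteroid dehydrogenase type 2 (Homo sapiens) (a higher number here means a weaker inhibitor, a lower number a stronger inhibitor), and they sit so close together that no order can be read from them; compound 2 shows the lower of the two numbers only by a margin inside the usual scatter, with compound 1 right beside it.

The next compound is compound 3, `Cc1cc(C)c(S(=O)(=O)Nc2cccc(O)c2)cc1C`. Compared with compound 2, the change is methyl in place of methoxy on an aromatic carbon. Among the measured compounds shown here, no measured pair in this set shows this kind of change, so there is no step to lean on. For the measured compounds named here, with only two near-identical values available, the safest expectation is a change no larger than the scatter, in no particular direction.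

For compound 3 in this assay the estimate is 7000 nM, with a range from 2500 nM to 20000 nM. The expected step from compound 2 to compound 3 is a 1.0-fold higher number from compound 2 to compound 3 (0.01 log units; within the scatter), essentially flat.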

Compound 3, half-maximal inhibitory concentration: 3300 nM
Compound 3: middle estimate off by 2.1-fold (0.33 log units), on the high side; the range from low to high includes it.
By their numbers in this assay, from the lowest: compound 3; then compounds 2 and 1 (each within the scatter of the next).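

In this assay, methyl in place of methoxy gives a 2.1-fold lower number from compound 2 to compound 3 (0.32 log units; beyond the scatter), a modest change but the first in this set to lie beyond the scatter. It shows that this aromatic carbon, ortho to a methyl group, meta to a methyl group and para to a large group, is not indifferent to what it carries, and that the smaller methyl is the better of the two groups tried there. No measurement shown here explains the step.

The swap removes the oxygen and its hydrogen-bond acceptor along with one heavy atom, so these two differences cannot be told apart from this single pair. On these data alone, whether a plain hydrogen, a chlorine, an ethyl chain or an amine on this carbon would lower the number further remains open.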